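Three neighbours at the ceiling of a cytotoxicity assay

The source may hold more compounds than are shown below. What is called first, only, known or untested is meant among the compounds shown, and "the series" means these compounds.

Of the compounds shown here, three have so far been tested in an ADME assay on MDBK cells (Bos taurus) for cytotoxicity; a higher number here means that more compound is tolerated, a lower number that less compound is tolerated. Compound 2 `Fc1cccc(Cn2ccc3nc(-c4ccccc4)nc-3c2)c1` gives > 100000 nM, which is a limit of the assay rather than a number. Compound 1 `Cc1ccn(Cc2c(F)cccc2F)c2nc(-c3c(F)cccc3F)nc1-2` likewise gives > 100000 nM, again a limit. Compound 3 `FC(F)(F)c1ccc(Cn2ccc3nc(-c4ccccc4)nc-3c2)cc1` gives 84000 nM. Compound 2 thus stands at the limit of > 100000 nM in this assay, at which 2 of the 3 values shown sit, so how much more of it would be tolerated is not pinned down. Compound 4 `C(=C/c1ccccc1)\Cn1ccc2nc(-c3ccccc3)nc-2c1` is the untested relative: 2-phenylethenyl in place of 3-fluorophenyl on a saturated chain carbon bound to an aromatic nitrogen. For the measured compounds named here, no measured pair shows what such a change does here, and the three measured compounds spread little. The expected step, a number no higher from compound 2 to compound 4 (the limit leaves the size open), is none beyond the usual scatter. Compound 4 is therefore expected to give about 100000 nM, within 40000 nM to 250000 nM.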

Compound 4, half-maximal cytotoxic concentration: 78000 nM
For compound 4 the middle estimate is 1.3-fold (0.11 log units) above the measured one, and the stated range covers the measured number.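

In this assay the change to 2-phenylethenyl on a saturated chain carbon bound to an aromatic nitrogen gives an at least 1.2-fold lower number from compound 2 to compound 4 (0.10 log units; that floor lies within the scatter) and replaces a limit with a real number. This position therefore accepts 2-phenylethenyl, and compound 4 is still tolerated at a high concentration. From the compounds shown here alone, the true size of the step remains unknown, and the floor is all that can be read: the limit of > 100000 nM in this assay, at which 2 of the 4 values shown sit.

Going by these compounds, whether an amine or a carboxylic acid at this position would be tolerated as well remains open. So does whether 2-phenylethenyl would behave the same way on the core of compound 1.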